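Same Halogen Swap, Tried Again on a Shifted Core

The compounds below may be only part of what the source reports. "The series", "measured", "known", "first", "only" and "open" are said of these compounds alone.

Three compounds sharing a sulfonyl-bearing two-ring core with a pendant aromatic ring have been tested in an ADME assay on microsomes from liver (Homo sapiens) for metabolic stability, tested at 2.5 uM; on this read-out higher numbers stand for fast clearance and lower numbers for slow clearance. Compound 1 `O=S(=O)(c1cc(F)cc(F)c1)c1cnc2cc(F)ccc2c1-c1ccc(Cl)cc1` gives 0.03 mL/min in this assay. Compound 2 `O=S(=O)(c1cc(F)cc(F)c1)c1cnc2cc(F)ccc2c1-c1cccc(F)c1` gives 0.06 mL/min in this assay. The two differ only by 4-chlorophenyl in place of 3-fluorophenyl on an aromatic carbon, and the step between them is a 2.0-fold lower number from compound 2 to compound 1 (0.30 log units; within the scatter). Compound 3 `O=S(=O)(c1cc(F)cc(F)c1)c1cnc2c(F)cccc2c1-c1cccc(F)c1` is made of the same atoms as compound 2 joined differently, with the fluorine on the core placed elsewhere; the difference between the two cores is not broken down here. In this assay compound 3 gives 1.18 mL/min, the highest of the three numbers and beyond the scatter from both compound 2 and compound 1.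

Compound 4 `O=S(=O)(c1cc(F)cc(F)c1)c1cnc2c(F)cccc2c1-c1ccc(Cl)cc1` has not yet been measured. It differs from compound 3 by 4-chlorophenyl in place of 3-fluorophenyl on an aromatic carbon, the same change, at the same place, as that leading from compound 2 to compound 1. Because that earlier step was a 2.0-fold lower number from compound 2 to compound 1 (0.30 log units; within the scatter) and within the scatter, compound 4 is expected to stay near compound 3. In this assay compound 4 is expected to give 0.7 mL/min, with a likely range from 0.3 mL/min to 1.6 mL/min. Going by the values given here, that estimate amounts to a step of a 1.7-fold lower number from compound 3 to compound 4 (0.23 log units; within the scatter), resting on the single earlier swap alone.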

Compound 4, intrinsic clearance in a liver preparation (reported as CLH), per the amount of preparation that the assay uses: 0.73 mL/min
The estimate for compound 4 lay 1.0-fold (0.02 log units) below the measured number, and the stated range covers the measured number.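

Replacing 3-fluorophenyl with 4-chlorophenyl on the core of compound 3 gives a 1.6-fold lower number from compound 3 to compound 4 (0.21 log units; within the scatter) in this assay, so the swap produces no readable change here. The two cores agree on this point, which means that, for these two pairs, the small effect of the swap carried over from one core to the other: the same change on two cores in this assay, a 2.0-fold lower number (0.30 log units; within the scatter) from compound 2 to compound 1 and a 1.6-fold lower number (0.21 log units; within the scatter) from compound 3 to compound 4, 1.2-fold (0.09 log units) apart, within the scatter of two such steps

This does not show that 4-chlorophenyl truly lowers clearance, since neither step rises above the noise of repeated measurements, and two pairs that differ only in where the core fluorine sits cannot establish a rule for other cores. The compounds shown leave open how this assay would respond to a methoxy group, a nitrile or an amine on the pendant ring in place of the halogen. They also leave open whether the swap would stay this small on a core with no fluorine at all, or with a carboxylic acid attached to it.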